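This account rests on a few compounds, and the source may have more. Where it says the series, first, only, none or still open, it means among the compounds named here.

Compound 1 `COc1cc2ncnc(Nc3cccc(Br)c3)c2cc1OCCCN1CCNCCNCCNCC1`: 14700 nM
Compound 2 `COc1cc2ncnc(Nc3ccc(F)c(Br)c3)c2cc1OCCCN1CCNCCNCCNCC1`: 11800 nM
Compound 3 `COc1cc2ncnc(Nc3cccc(C(F)(F)F)c3)c2cc1OCCCN1CCNCCNCCNCC1`: 15700 nM

In a functional assay on A549 cells (Homo sapiens) for antiproliferative activity, read by MTT assay, with a stated time of 72 h (a lower number here means a stronger inhibitor, a higher number a weaker inhibitor), compound 1 gives 14700 nM. Its neighbours sit close: a 1.2-fold lower number from compound 1 to compound 2 (0.10 log units; within the scatter) and a 1.1-fold higher number from compound 1 to compound 3 (0.03 log units; within the scatter), so the three measured compounds cannot be ordered. Compound 4 `COc1cc2ncnc(Nc3cccc(F)c3)c2cc1OCCCN1CCNCCNCCNCC1` differs from compound 1 in one place: fluoro in place of bromo on an aromatic carbon. The most relevant measured step is a 1.1-fold higher number from compound 1 to compound 3 (0.03 log units; within the scatter), where another group replaced the same bromo with no change beyond the scatter; a 1.2-fold lower number from compound 1 to compound 2 (0.10 log units; within the scatter) shows a fluoro entering elsewhere with the same result. Compound 4 is therefore expected to stay within the scatter of compound 1, with a 1.1-fold higher number from compound 1 to compound 4 (0.04 log units; within the scatter). The estimate for compound 4 is 16000 nM, ranging from 8000 nM to 32000 nM.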

Compound 4, half-maximal inhibitory concentration: > 50000 nM
Compound 4: only a limit was reported; the forecaster's own chance of this, stated with the estimate: 5%; at least 3.1-fold (0.49 log units) between middle value and limit.
By their numbers in this assay, from the lowest: compounds 2, 1 and 3 (each within the scatter of the next). At a limit, above all of these: compound 4.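

The value of compound 4 is a limit: the limit of > 50000 nM in this assay, at which 1 of the 4 values shown sits. In this assay, this position proves sensitive to the group it carries: fluoro in place of bromo gives an at least 3.4-fold higher number from compound 1 to compound 4 (0.53 log units; beyond the scatter), and fluoro in place of trifluoromethyl gives an at least 3.1-fold higher number from compound 3 to compound 4 (0.50 log units; beyond the scatter), although bromo and trifluoromethyl had stayed within the scatter of each other. The 3-fluorophenyl group likewise gives an at least 4.2-fold higher number from compound 2 to compound 4 (0.62 log units; beyond the scatter) when it stands in place of 3-bromo-4-fluorophenyl. The compounds shown leave open whether a chloro, methyl or methoxy group here would match bromo or fall with fluoro.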